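The source may hold more compounds than are shown below. What is called first, only, known or untested is meant among the compounds shown, and "the series" means these compounds.

Among the compounds with values here, in an ADME assay on MT4 cells (Homo sapiens) for cytotoxicity, read by MTT assay (a lower number here means that less compound is tolerated, a higher number that more compound is tolerated), compound 1 `Cc1cc(C)cc(S(=O)(=O)c2c(C(=O)NCC(=O)NC(C)c3ccccc3)[nH]c3ccc(Cl)cc23)c1` gives 29400 nM, the only exact value so far. Compound 2 `Cc1cc(C)cc(S(=O)(=O)c2c(C(=O)NC(C)c3ccco3)[nH]c3ccc(Cl)cc23)c1` is reported only as a limit, > 54700 nM. Compound 3 `Cc1cc(C)cc(S(=O)(=O)c2c(C(=O)NCC(=O)NCc3ccccc3F)[nH]c3ccc(Cl)cc23)c1` is likewise only a limit, > 47300 nM. Compound 4 `Cc1cc(C)cc(S(=O)(=O)c2c(C(=O)NCc3ccc4nc(N)[nH]c4c3)[nH]c3ccc(Cl)cc23)c1` carries 2-amino-1H-benzimidazol-6-yl in place of (2-fluorobenzyl)carbamoyl on a saturated chain carbon bound to an amide-type nitrogen. The nearest measured changes are an at least 1.6-fold higher number from compound 1 to compound 3 (0.20 log units; that floor lies within the scatter) and an at least 1.8-fold higher number from compound 1 to compound 2 (0.26 log units; that floor lies within the scatter), both floors within the scatter, and neither introduces this group. With compound 1 at 29400 nM as the sole anchor, a modest downward move is expected, an at least 1.4-fold lower number from compound 3 to compound 4 (0.16 log units; that floor lies within the scatter). For compound 4 the estimated value is 32000 nM, with an expected range from 10000 nM to 60000 nM.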

Compound 4, half-maximal cytotoxic concentration: 5890 nM
For compound 4 the middle estimate is 5.4-fold (0.74 log units) above the measured one; measured number outside the range, below it.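

In this assay, within the data shown here, 2-amino-1H-benzimidazol-6-yl on a saturated chain carbon bound to an amide-type nitrogen gives the first steps beyond the scatter, where the earlier floors stayed within it: a 5.0-fold lower number from compound 1 to compound 4 (0.70 log units; beyond the scatter), an at least 8.0-fold lower number from compound 3 to compound 4 (0.90 log units; beyond the scatter) and an at least 9.2-fold lower number from compound 2 to compound 4 (0.96 log units; beyond the scatter). The value of compound 3 is only a limit: the limit of > 47300 nM in this assay, at which 1 of the 4 values shown sits. The value of compound 2 is also only a limit: the limit of > 54700 nM in this assay, at which 1 of the 4 values shown sits.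

The compounds shown leave open whether the lower number follows the amine of this group or its two aromatic rings. A benzimidazol-6-yl group without the amine, or a longer chain to the same rings, would separate these readings.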